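The source may hold more compounds than are shown below. What is called first, only, known or untested is meant among the compounds shown, and "the series" means these compounds.

Compound 1, `Fc1ccc(C2(c3ccc(F)cc3)CNC(c3cccc(Br)c3)=N2)cc1`, in an assay on LM cells for displacement of a labelled ligand from Neuropeptide Y receptor type 5 (Homo sapiens) (on this read-out higher numbers stand for weaker inhibition and lower numbers for stronger inhibition), gives 4.8 nM.
Compound 2, `Fc1ccc(C2(c3ccc(F)cc3)CNC(c3ccccn3)=N2)cc1`, in this assay gives 160 nM.
Compound 3, `Fc1ccc(C2(c3ccc(F)cc3)CNC(c3ccncc3)=N2)cc1`, in this assay gives 160 nM.

Compound 3 stands level with compound 2 at the digits shown, the two of them together giving the highest numbers among the three measured compounds; the step of no change at the digits printed from compound 2 to compound 3 (within the scatter) is within the scatter. Compound 1 is the furthest away: the step of a 33-fold higher number from compound 1 to compound 3 (1.52 log units; beyond the scatter) is large, as is the parallel step a 33-fold higher number from compound 1 to compound 2 (1.52 log units; beyond the scatter).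

Compound 4 is `Fc1ccc(C2(c3ccc(F)cc3)CNC(c3cncnc3)=N2)cc1`. It differs from compound 3 in one place: pyrimidin-5-yl in place of pyridin-4-yl on a carbon with a double bond to nitrogen.

Going by the values given here, two measured steps bear on this change. The step from compound 2 to compound 3 shows that moving the single ring nitrogen of the six-membered aromatic ring at this carbon made no difference beyond the scatter. The steps from compound 1 to compound 2 and to compound 3 show that exchanging 3-bromophenyl for a ring with one hetero atom gave a large increase in the number. Adding a second hetero atom is expected to move the number further in that direction, though by a smaller amount. Compound 4 is therefore expected to give 320 nM in this assay, in the range 100 nM to 1000 nM. The expected step of a 2.0-fold higher number from compound 3 to compound 4 (0.30 log units; within the scatter) would thus be modest and upward.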

Compound 4, half-maximal inhibitory concentration: 47 nM
Estimate against measurement, compound 4: 6.8-fold (0.83 log units) above; the measured number lies below the stated range.
By their numbers in this assay, from the lowest: compound 1; then compound 4; then compounds 2 and 3 (each within the scatter of the next).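

In this assay the ring at this carbon, which lies between two ring nitrogen atoms, proves sensitive to its hetero atoms: pyrimidin-5-yl gives a 3.4-fold lower number from compound 3 to compound 4 (0.53 log units; beyond the scatter) and a 3.4-fold lower number from compound 2 to compound 4 (0.53 log units; beyond the scatter), whereas the two pyridinyl rings could not be told apart. A ring with 2 hetero atoms therefore recovers part of what the rings with 1 hetero atom lost, so adding a hetero atom does not simply push the number upward, yet 3-bromophenyl still keeps its lead with a 9.8-fold higher number from compound 1 to compound 4 (0.99 log units; beyond the scatter). Nothing available here explains why pyrimidin-5-yl gives the lower number.

The compounds shown leave open whether pyridin-3-yl would stand with compound 4 or with compounds 2 and 3, a comparison that would help separate the number of ring nitrogens from where they are placed. They also leave open whether an amine or a methoxy group on the pyrimidin-5-yl ring would narrow the remaining gap to compound 1.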